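This account rests on a few compounds, and the source may have more. Where it says the series, first, only, none or still open, it means among the compounds named here.

Two compounds of this series have so far been run in a functional assay on A-375 cells (Homo sapiens) for cytotoxicity, read by MTT assay, with a stated time of 72 h, tested at 3 uM; a lower number here means less inhibition of growth, a higher number more inhibition of growth at the concentration tested. Compound 1 `N/C(=N\NC(=S)N1CCN(c2ccccn2)CC1)c1ccc(F)cn1` gives 53.1%, while compound 2 `Cc1ccnc(/C(N)=N/NC(=S)N2CCOCC2)c1` gives 66.6%. Compound 1 stands lowest of the two, and compound 2 sits above it by a gap beyond the usual scatter. For the measured compounds named here, no step between two measured compounds differing in one place is available. Compound 3 `N/C(=N\NC(=S)N1CCN(c2ccccn2)CC1)c1ccccn1`, not yet measured, differs from compound 1 by hydrogen in place of fluoro on an aromatic carbon. Going by the values given here, with no comparable step on record, the expected change is small, with no clear direction and within the scatter. Compound 3 is expected to give 50%, within 35% to 65%, an estimated step of a number 3.1 percentage points lower from compound 1 to compound 3 (within the scatter).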

Compound 3, percent growth inhibition at one concentration: 73.7%
The estimate for compound 3 lay 23.7 percentage points below the measured number; measured number above the stated range.
By their numbers in this assay, from the lowest: compound 1; then compounds 2 and 3 (each within the scatter of the next).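

In this assay, going from 5-fluoropyridin-2-yl to pyridin-2-yl gives a step of a number 20.6 percentage points higher from compound 1 to compound 3 (beyond the scatter), so this place, para to a large group, is not silent in this series. For the compounds shown here, this is the first single-place comparison, and here hydrogen gives more inhibition of growth than fluoro. No available data account for the step.

On these data alone, whether chloro, methyl or an amine at this place would fall nearer to fluoro or to hydrogen stays open. So does whether the same change gives a similar step on any compound other than compound 1.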